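Swapping Methoxyphenyl for Chlorophenyl: Expected Lipophilicity

The compounds below may be only part of what the source reports. "The series", "measured", "known", "first", "only" and "open" are said of these compounds alone.

Compound 2 `CC[C@@H](Nc1c(C#N)c(-c2ccc(-c3cccc(OC)c3)cc2)nc2cnccc12)C(N)=O` sits at the low end of the three measured numbers. In a physicochemical assay for lipophilicity, read by HPLC, at pH 7.5 (on this read-out lower numbers stand for lower lipophilicity and higher numbers for higher lipophilicity), compound 2 gives 2.7. Compound 1 `CCOc1ccccc1-c1ccc(-c2nc3cnccc3c(NC(C(N)=O)C3CC3)c2C#N)cc1` gives 3 in this assay, a number within the usual scatter of compound 2, while compound 3 `CCOc1ccccc1-c1ccc(-c2nc3cnccc3cc2C#N)cc1` gives 3.8, clearly higher. Among the measured compounds shown here, the only measured step, a number 0.80 log units higher from compound 1 to compound 3 (beyond the scatter), concerns a different part of the shared core and does not touch the group changed here. Compound 4 `CC[C@@H](Nc1c(C#N)c(-c2ccc(-c3ccc(Cl)cc3)cc2)nc2cnccc12)C(N)=O` differs from compound 2 in one place: 4-chlorophenyl in place of 3-methoxyphenyl on an aromatic carbon. For the measured compounds named here, no measured step bears directly on this change, so the expectation rests on the structural change alone. A modest rise is expected, a number 0.60 log units higher from compound 2 to compound 4 (beyond the scatter). Compound 4 is estimated at 3.3, between 2.9 and 3.8.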

Compound 4, distribution coefficient: 3.1
The estimate for compound 4 lay 0.20 log units above the measured number; low and high end bracket the measured number.
By their numbers in this assay, from the lowest: compounds 2, 1 and 4 (each within the scatter of the next, the first and the last beyond it); then compound 3.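

Among the compounds shown here, this is the first measured step at this position: in this assay, 4-chlorophenyl in place of 3-methoxyphenyl gives a number 0.40 log units higher from compound 2 to compound 4 (beyond the scatter). The swap alters both the group on the outer ring and where that group sits, so the step cannot be assigned to either change alone. No measurement at hand explains this step.

From the compounds shown here alone, whether the group or its place matters more stays open, and 3-chlorophenyl or 4-methoxyphenyl could separate the two. Going by these compounds, how an amine or a carboxylic acid on this ring would read also remains unknown.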